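Hydrazone aryl series: one hydroxy of compound 3 swapped for fluoro

This account rests on a few compounds, and the source may have more. Where it says the series, first, only, none or still open, it means among the compounds named here.

The compounds share one core and differ only on the aryl attached to the carbon with a double bond to nitrogen. In a functional assay on U-87MG ATCC cells (Homo sapiens) for cytotoxicity, read by MTT assay, with a stated time of 72 h (on this read-out lower numbers stand for stronger inhibition and higher numbers for weaker inhibition), compound 1 `CN(C)CCn1cnnc1-c1cc(Oc2ccc(NC(=O)N/N=C/c3ccc(Cl)cc3Cl)cc2F)ccn1` gives 2330 nM and compound 2 `CN(C)CCn1cnnc1-c1cc(Oc2ccc(NC(=O)N/N=C/c3ccc(F)cc3F)cc2F)ccn1` gives 1900 nM; the step of a 1.2-fold lower number from compound 1 to compound 2 (0.09 log units; within the scatter) stays within the scatter. Compound 3 `CN(C)CCn1cnnc1-c1cc(Oc2ccc(NC(=O)N/N=C/c3ccc(O)c(O)c3)cc2F)ccn1` sits at the limit of > 100000 nM in this assay, at which 1 of the 3 values shown sits, and its > 100000 nM is a limit of the assay, not a number. Compound 4 `CN(C)CCn1cnnc1-c1cc(Oc2ccc(NC(=O)N/N=C/c3ccc(O)c(F)c3)cc2F)ccn1` differs from compound 3 by fluoro in place of hydroxy on an aromatic carbon. The steps bearing on this change are an at least 42-fold higher number from compound 1 to compound 3 (1.63 log units; beyond the scatter) and an at least 52-fold higher number from compound 2 to compound 3 (1.72 log units; beyond the scatter), both large and both toward the dihydroxyphenyl; moving compound 4 partway back toward a halogenated aryl, a partial recovery is expected. Compound 4 is therefore estimated at 20000 nM, with a range of 5000 nM to 100000 nM. The expected step is an at least 5.0-fold lower number from compound 3 to compound 4 (0.69 log units; beyond the scatter).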

Compound 4, half-maximal inhibitory concentration: > 100000 nM
Compound 4 gave a limit, no number (the forecaster's own chance of this, stated with the estimate: 30%); middle value at least 5.0-fold (0.69 log units) away from the limit.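

In this assay compound 4, like compound 3, stands at a limit of the assay, so fluoro in place of hydroxy gives no visible recovery, and the step between these two limits cannot be read. Removing one hydroxy does not restore the level of the dihalogenated aryls: an at least 52-fold higher number from compound 2 to compound 4 (1.72 log units; beyond the scatter), and an at least 42-fold higher number from compound 1 to compound 4 (1.63 log units; beyond the scatter). The loss therefore does not require the 3,4-dihydroxyphenyl, since the 3-fluoro-4-hydroxyphenyl shares it, and the series now reads: the limit of > 100000 nM in this assay, at which 2 of the 4 values shown sit.

From the compounds shown here alone, how far compound 3 and compound 4 lie beyond the limit remains open. Also open, going by these compounds, is whether the remaining hydroxy accounts for the loss, a question that a methoxy group in its place would address.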